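The source may hold more compounds than are shown below. What is called first, only, known or untested is meant among the compounds shown, and "the series" means these compounds.

The series was examined in a functional assay on MDA-MB-231 cells (Homo sapiens) for cytotoxicity, read by sulforhodamine B assay, with a stated time of 72 h; a lower number here means a stronger inhibitor of growth, a higher number a weaker inhibitor of growth. Compound 2 `O=C(Nc1cc(C(F)(F)F)cc(C(F)(F)F)c1)C1CCc2ccccc2N1C(=O)c1ccc(Cl)cc1` gives 2000 nM in this assay. Compound 3 `O=C(Nc1ccccc1C(F)(F)F)C1CCc2ccccc2N1C(=O)c1ccc(Cl)cc1` differs from compound 2 in a way that is not broken down here; in this assay compound 3 gives 533 nM. For compound 1 `CC(=O)N1c2ccccc2CCC1C(=O)Nc1cc(C(F)(F)F)cc(C(F)(F)F)c1` the outcome in this assay is a limit rather than a number, > 70000 nM, as shown by the limit of > 70000 nM in this assay, at which 1 of the 3 values shown sits.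

Compound 1 and compound 2 differ by a single change, (methyl in place of 4-chlorophenyl on a carbonyl carbon). The step of an at least 35-fold higher number from compound 2 to compound 1 (1.54 log units; beyond the scatter) therefore spans the gap between a number and a limit. Compound 3 sits at the lowest number among the two numbers seen, and compound 2 stands a step above it.

Compound 4 `CC(=O)N1c2ccccc2CCC1C(=O)Nc1ccccc1C(F)(F)F` is unmeasured in this assay. It differs from compound 3 by methyl in place of 4-chlorophenyl on a carbonyl carbon, which is the same change that separates compound 2 from compound 1, at the same place. The expectation for compound 4 rests on compound 3 giving 533 nM and on the size of the step of an at least 35-fold higher number from compound 2 to compound 1 (1.54 log units; beyond the scatter) seen once with this change. Compound 4 is therefore expected to show a step of about a 56-fold higher number from compound 3 to compound 4 (1.75 log units; beyond the scatter) in this assay. The estimate for compound 4 is 30000 nM, with a range from 8000 nM to 80000 nM, and the result may well emerge only as a limit.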

Compound 4, concentration for 50% growth inhibition: > 80000 nM
Compound 4: a limit, no number; the forecaster's own chance of this, stated with the estimate: 40%; at least 2.6-fold (0.42 log units) between middle value and limit.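

Compound 4 returned only a limit in this assay, > 80000 nM, and not a number. Putting methyl in place of 4-chlorophenyl on the carbonyl carbon gave an at least 150-fold higher number from compound 3 to compound 4 (2.17 log units; beyond the scatter), so the large rise seen on one core recurred on the other, and on both cores the acetyl compound ended at a limit rather than a number: the same change on two cores in this assay, an at least 35-fold higher number (1.54 log units; beyond the scatter) from compound 2 to compound 1 and an at least 150-fold higher number (2.17 log units; beyond the scatter) from compound 3 to compound 4; the limit leaves it open whether they differ This shows that the direction of the change carried from one core to the other in these two pairs, but it does not show the true size of the step on either core or whether the two sizes match, and it gives no reason for the loss of growth inhibition.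

The compounds shown leave open how much of the effect belongs to the ring and how much to the chlorine, as the only groups on this carbonyl carbon are 4-chlorophenyl and methyl, and a plain phenyl or a 4-fluorophenyl does not appear among them. Also open, on these data alone, is whether a longer alkyl chain or a benzyl group in the same place would restore any of the growth inhibition seen with 4-chlorophenyl.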